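Swapping Diethylamino for 4-Methylpiperazin-1-yl on a Longer Side Chain

A few compounds are considered here, and "the series" means these few. Any claim that something is new, unique, unknown or untested is made for them only; others in the source may bear on it.

Compound 1 `CCN(CC)CCn1c(N)c(-c2nc3ccccc3[nH]2)c2nc(C#N)c(C#N)nc21` carries a diethylamino group two bonds along a saturated chain from an aromatic nitrogen. In a functional assay on HL-60 cells (Homo sapiens) for antiproliferative activity, read by MTT assay, with a stated time of 48 h (on this read-out lower numbers stand for stronger inhibition and higher numbers for weaker inhibition), compound 1 gives 1880 nM. Compound 2 `CN1CCN(CCn2c(N)c(-c3nc4ccccc4[nH]3)c3nc(C#N)c(C#N)nc32)CC1` differs by 4-methylpiperazin-1-yl in place of diethylamino on a saturated chain carbon, two bonds along the chain from an aromatic nitrogen, and that change produced a 2.3-fold higher number from compound 1 to compound 2 (0.36 log units; beyond the scatter). In this assay compound 2 gives 4300 nM. Compound 3 `CCN(CC)CCCn1c(N)c(-c2nc3ccccc3[nH]2)c2nc(C#N)c(C#N)nc21` differs from compound 1 by (diethylamino)methyl in place of diethylamino on a saturated chain carbon, two bonds along the chain from an aromatic nitrogen, so its chain is one carbon longer. In this assay compound 3 gives only a limit, > 730 nM, not a number; (the limit of > 730 nM in this assay, at which 1 of the 3 values shown sits). Compound 4 `CN1CCN(CCCn2c(N)c(-c3nc4ccccc4[nH]3)c3nc(C#N)c(C#N)nc32)CC1` is not yet measured. It differs from compound 3 by 4-methylpiperazin-1-yl in place of diethylamino on a saturated chain carbon, three bonds along the chain from an aromatic nitrogen; this is the same kind of change as from compound 1 to compound 2, though the place is three bonds along the chain from the aromatic nitrogen rather than two. The step from compound 3 to compound 4 is estimated as a step that the limit leaves unreadable from compound 3 to compound 4. Because a 2.3-fold higher number from compound 1 to compound 2 (0.36 log units; beyond the scatter) moved toward a higher number, compound 4 is expected to give 5000 nM, likely between 1200 nM and 25000 nM, and most probably again only a limit.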

Compound 4, half-maximal inhibitory concentration: 750 nM
Compound 4: the middle estimate sits 6.7-fold (0.82 log units) above what was measured; measured number below the stated range.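

In this assay, extending the chain while keeping the 4-methylpiperazin-1-yl group gives a 5.7-fold lower number from compound 2 to compound 4 (0.76 log units; beyond the scatter) and replacing the 2-(diethylamino)ethyl group with the 3-(4-methylpiperazin-1-yl)propyl group gives a 2.5-fold lower number from compound 1 to compound 4 (0.40 log units; beyond the scatter) as well. Both steps describe only these compounds on the shared core, so they show that the 4-methylpiperazin-1-yl group can sit on the longer chain with a lower number than on the shorter one. They do not show whether swapping diethylamino for 4-methylpiperazin-1-yl has the same effect on both chains, because no step to or from compound 3 can be read, as compound 3 has only a limit: the limit of > 730 nM in this assay, at which 1 of the 4 values shown sits.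

The compounds shown leave open how a morpholin-4-yl or pyrrolidin-1-yl group would compare with these two amines on either chain. They also leave open whether a four-carbon chain would lower the number further.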